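The compounds below may be only part of what the source reports. "The series", "measured", "known", "first", "only" and "open" are said of these compounds alone.

Compound 3 `C=CCSc1nnc(CCC)n1N1C(=O)c2ccccc2C1=O` belongs to a set of three analogues built on one shared core. In a functional assay on HepG2 cells (Homo sapiens) for cytotoxicity, read by MTT assay, with a stated time of 48 h (on this read-out lower numbers stand for stronger inhibition and higher numbers for weaker inhibition), compound 3 gives only a limit of the assay, > 200000 nM. Compound 1 `C=CCSc1nnc(CC)n1N1C(=O)c2ccccc2C1=O` likewise gives only a limit, > 200000 nM. Compound 2 `CCc1nnc(SCC(=O)c2ccc(C)cc2)n1N1C(=O)c2ccccc2C1=O` also gives only a limit, > 200000 nM. The change from compound 3 to compound 4 `CCCc1nnc(SCC(=O)c2ccc(C)cc2)n1N1C(=O)c2ccccc2C1=O` is (4-methylphenyl)carbonyl in place of vinyl on a saturated chain carbon bound to a sulfur. The same change has been made once before, as a step that the two limits leave unreadable from compound 1 to compound 2, and the step that the two limits leave unreadable from compound 1 to compound 3 is equally unreadable, since (the limit of > 200000 nM in this assay, at which 3 of the 3 values shown sit). The expected step of a number no higher from compound 3 to compound 4 (the limit leaves the size open) can therefore be given no readable direction or size, only the expectation that the limit is met again. Compound 4 is estimated at 200000 nM, with a range from 100000 nM to 400000 nM.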

Compound 4, half-maximal inhibitory concentration: > 200000 nM
Compound 4: no number, only a limit (the forecaster's own chance of this, stated with the estimate: 85%); the middle value lies on the limit itself.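

Neither step to compound 4, from compound 3 or from compound 2, can be read in this assay, as each compound gives only a limit: the limit of > 200000 nM in this assay, at which 4 of the 4 values shown sit.

The compounds shown leave open whether either change alters cytotoxicity at all.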